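Phenyl to methyl on the ring nitrogen of compound 3

This account rests on a few compounds, and the source may have more. Where it says the series, first, only, none or still open, it means among the compounds named here.

Measured so far in an ADME assay on BHK-21 cells (Mesocricetus auratus) for cytotoxicity, read by MTT assay, with a stated time of 96 h; on this read-out lower numbers stand for higher toxicity in this test and higher numbers for lower toxicity in this test:
- compound 1 `Fc1ccc(F)c(/N=N/c2ccc(NC[C@@H]3CCCN4CCCC[C@H]34)c3c2CCCC3)c1`: 38000 nM
- compound 2 `Cc1ccc(/N=N/c2ccc(NCCCN(C)C)cc2)cc1`: > 100000 nM (a limit)
- compound 3 `c1ccc(/N=N/N2CCN(c3ccccc3)CC2)cc1`: > 100000 nM (a limit)

In this assay compound 3 gives > 100000 nM, which is a limit and not a number. In the same test compound 2 gives > 100000 nM, which is also a limit. The two therefore share (the limit of > 100000 nM in this assay, at which 2 of the 3 values shown sit). Among the three, only compound 1 has a numerical value, 38000 nM.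

The next structure is compound 4 `CN1CCN(/N=N/c2ccccc2)CC1`, which differs from compound 3 as follows: methyl in place of phenyl on an amine nitrogen in a ring. In words, this is methyl in place of phenyl on an amine nitrogen in a ring. Within the data shown here, no measured pair shows this change, so no step beyond the usual scatter is expected in this assay, in either direction. The expected change is a number no higher from compound 3 to compound 4 (the limit leaves the size open). The estimated value for compound 4 is 100000 nM, with an expected range of 40000 nM to 250000 nM.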

Compound 4, half-maximal cytotoxic concentration: 70000 nM
Compound 4: middle estimate off by 1.4-fold (0.15 log units), on the high side; the measured number falls inside the stated range.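

In this assay, methyl in place of phenyl on the amine nitrogen in a ring gives an at least 1.4-fold lower number from compound 3 to compound 4 (0.15 log units; that floor lies within the scatter) and stays within the scatter at its floor. Compound 4 gives 70000 nM as a number, so this change brings the position within the measurable range of the test, which compound 3 did not show. The true size of the step remains unknown because compound 3 gives a limit and not a number: the limit of > 100000 nM in this assay, at which 2 of the 4 values shown sit.

With a single change at this position, no trend across groups on this ring nitrogen can be drawn. Going by these compounds, it remains open whether an ethyl group, a longer chain or an acetyl group there would give a step clearly beyond the scatter.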